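Replacing ethoxy with ethyl in compound 2

The source may report more compounds than this note shows. Statements on the series, on what has been measured and on what is new or still open speak of the compounds shown alone.

In an in vitro ADME assay on microsomes from liver (Mus musculus) for metabolic stability (a lower number here means slower removal, a higher number faster removal of the compound), compound 1 `Cc1cc(Nc2cccc(Cl)c2)n2nc(C(C)(F)F)nc2n1` gives 72.2 mL.min-1.g-1, while compound 2 `CCOc1nc2nc(C)cc(Nc3ccc(C(F)(F)F)cc3)n2n1` gives 14.4 mL.min-1.g-1, the lower of the two numbers and beyond the scatter of compound 1. Compound 3 `CCc1nc2nc(C)cc(Nc3ccc(C(F)(F)F)cc3)n2n1` carries ethyl in place of ethoxy on an aromatic carbon of the shared core: ethyl in place of ethoxy on an aromatic carbon. For the measured compounds named here, no measured pair isolates this change, so the expectation starts from compound 2 at 14.4 mL.min-1.g-1. In this assay, no step beyond the scatter is expected, and the estimated step is a 1.1-fold higher number from compound 2 to compound 3 (0.05 log units; within the scatter). For compound 3 the estimated clearance is 16 mL.min-1.g-1, with an expected range of 7 mL.min-1.g-1 to 38 mL.min-1.g-1.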

Compound 3, intrinsic clearance in microsomes: 14.4 mL.min-1.g-1
Compound 3: the middle estimate sits 1.1-fold (0.05 log units) above what was measured; measured number inside the range.
By their numbers in this assay, from the lowest: compounds 2 and 3 (each within the scatter of the next); then compound 1.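

In this assay, for the compounds shown here, ethyl in place of ethoxy gives no change at the digits printed from compound 2 to compound 3 (within the scatter), the first step that isolates this position between two ring nitrogen atoms. For this pair, the ethoxy oxygen can be removed with no change beyond the scatter, although the result rests on a single pair. No supporting measurement bears on why the number holds. Still open, from the compounds shown here alone, is whether a longer chain, an amine or a carboxylic acid at this position would leave the clearance equally unchanged. Going by these compounds, whether the ethyl-for-ethoxy result carries over to other substituents elsewhere on the shared core also remains open.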